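The compounds below may be only part of what the source reports. "The series", "measured", "known", "first", "only" and "open" are said of these compounds alone.

In an ADME assay on HEL cells (Homo sapiens) for cytotoxicity (a lower number here means that less compound is tolerated, a higher number that more compound is tolerated), compound 3 `CC(C)(C)c1ccc(OCCCCCn2ccc(=O)[nH]c2=O)cc1` gives 40000 nM. Going by the values given here, that is the only actual number among the three measured compounds. Compound 1 `Cc1ccccc1OCCCCCn1ccc(=O)[nH]c1=O` reaches only a limit of the assay, > 100000 nM. Compound 2 `Cc1cn(CCCCCOc2ccc(Br)cc2)c(=O)[nH]c1=O` likewise reaches only a limit, > 100000 nM. Compound 4 `O=c1ccn(CCCCCOc2ccccc2)c(=O)[nH]1` differs from compound 3 in one place: hydrogen in place of tert-butyl on an aromatic carbon. Among the compounds with values here, no two measured compounds differ from each other in a single place, so no measured step guides this change directly. Since two of the three values sit at the limit of > 100000 nM in this assay, at which 2 of the 3 values shown sit, compound 4 is expected to be tolerated at a higher concentration than compound 3. The step of a 2.5-fold higher number from compound 3 to compound 4 (0.40 log units; beyond the scatter) is expected to go upward, beyond the usual scatter. Compound 4 is estimated at 100000 nM, likely between 40000 nM and 300000 nM, with a fair chance that only a limit is reported.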

Compound 4, half-maximal cytotoxic concentration: > 100000 nM
Compound 4 gave a limit, no number; the forecaster's own chance of this, stated with the estimate: 60%; the middle value lies on the limit itself.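

In this assay, hydrogen in place of tert-butyl on this aromatic carbon gives an at least 2.5-fold higher number from compound 3 to compound 4 (0.39 log units; beyond the scatter), so what sits at this position does affect how much compound the cells tolerate. The full size of the step stays hidden, as the result for compound 4 is a limit of the assay and not a number: the limit of > 100000 nM in this assay, at which 3 of the 4 values shown sit. The step from compound 1 to compound 4 cannot be read, as both results are limits.

This finding rests on a single pair of compounds. On these data alone, it remains open how an amine or a carboxylic acid on this aromatic carbon would compare with tert-butyl.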